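Swapping bromo for fluoro on a chalcone-type antiproliferative

The source may report more compounds than this note shows. Statements on the series, on what has been measured and on what is new or still open speak of the compounds shown alone.

Measured so far:
compound 1, `O=C(COc1ccc(C(=O)/C=C/c2cccc(Br)c2)cc1)N[C@H]1CCOC1=O`: 9800 nM
compound 2, `O=C(COc1ccc(C(=O)/C=C/c2ccc(Br)cc2)cc1)N[C@H]1CCOC1=O`: 51700 nM

Among the measured compounds shown here, in a functional assay on DU-145 cells (Homo sapiens) for antiproliferative activity, read by MTT assay, with a stated time of 72 h (a higher number here means a weaker inhibitor, a lower number a stronger inhibitor), compound 2 gives 51700 nM, the higher of the two numbers; the only neighbour is compound 1, reached through a 5.3-fold higher number from compound 1 to compound 2 (0.72 log units; beyond the scatter). Compound 3, `O=C(COc1ccc(C(=O)/C=C/c2ccc(F)cc2)cc1)N[C@H]1CCOC1=O`, is not yet measured. It differs from compound 2 by fluoro in place of bromo on an aromatic carbon, on the aromatic carbon para to a large group. No measured step swaps one halogen for another, so nothing shown bears directly on this change; the single step seen concerns only where the bromo sits. With no guide, compound 3 is expected to stay close to compound 2, giving a 1.3-fold lower number from compound 2 to compound 3 (0.11 log units; within the scatter) and an estimated 40000 nM, within 10000 nM to 150000 nM.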

Compound 3, half-maximal inhibitory concentration: 18800 nM
Estimate against measurement, compound 3: 2.1-fold (0.33 log units) above; measured number inside the range.
By their numbers in this assay, from the lowest: compounds 1 and 3 (each within the scatter of the next); then compound 2.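

In this assay, the halogen itself counts at this aromatic carbon: fluoro in place of bromo gives a 2.8-fold lower number from compound 2 to compound 3 (0.44 log units; beyond the scatter) and is the first halogen swap shown. The step of a 1.9-fold higher number from compound 1 to compound 3 (0.28 log units; within the scatter) stays within the usual scatter, so a 4-fluorophenyl and a 3-bromophenyl cannot be told apart here. Nothing measured explains why the swap changes the number. Going by these compounds, whether a chloro group, a methoxy group or an amine at this carbon would give a lower number stays open. So does the effect of moving the fluoro elsewhere on the ring.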